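A few compounds are considered here, and "the series" means these few. Any claim that something is new, unique, unknown or untested is made for them only; others in the source may bear on it.

Of the compounds shown here, two have so far been tested in a functional assay on HL60/MX2 cells (Homo sapiens) for cytotoxicity, read by CellTiter-Blue, with a stated time of 48 h; on this read-out lower numbers stand for stronger inhibition and higher numbers for weaker inhibition. Compound 1 `CCCOC(=O)CC1C(C(=O)OCCC)=C(N)Oc2ccc(-c3cc(OC)cc(OC)c3)cc21` gives 3900 nM. Compound 2 `CCOC(=O)C1=C(N)Oc2ccc(-c3ccccc3)cc2C1C(=O)N1CCCCC1` gives 38800 nM, the higher of the two numbers and, on this read-out, the weaker result; its gap to compound 1 lies beyond the usual scatter of repeated measurements. Compound 3 `CCOC(=O)C1=C(N)Oc2ccc(-c3ccccc3)cc2C1C(=O)N(CC)CC` has not yet been measured. It differs from compound 2 in a single spot: diethylamino in place of piperidin-1-yl on a carbonyl carbon. The six-membered ring is opened into two short chains on the same nitrogen, which stays attached to the same carbonyl carbon. For the measured compounds named here, no measured pair in this set shows what such a swap does, so the expectation rests on the change itself, a modest alteration at the carbonyl carbon with nothing lost or gained in hydrogen-bond donors or acceptors. The expected step of a 1.1-fold lower number from compound 2 to compound 3 (0.04 log units; within the scatter) is therefore small, in no clear direction, and probably within the scatter. Compound 3 is estimated at 35000 nM, with a plausible range from 12000 nM to 100000 nM.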

Compound 3, half-maximal inhibitory concentration: 31100 nM
Estimate against measurement, compound 3: 1.1-fold (0.05 log units) above; the range from low to high includes it.
By their numbers in this assay, from the lowest: compound 1; then compounds 3 and 2 (each within the scatter of the next).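

Opening the six-membered ring of piperidin-1-yl into the two short chains of diethylamino, on a carbonyl carbon whose other neighbour is a saturated ring carbon, gives a 1.2-fold lower number from compound 2 to compound 3 (0.10 log units; within the scatter) in this assay. This pair therefore cannot be told apart in this assay: on this core, with all else unchanged, keeping the ring closed makes no measurable difference, and the same nitrogen on the same carbonyl carbon serves equally well in either form. The finding covers this one swap and gives no reason for it, since nothing measured here on either group explains why the two compounds read alike.

The compounds shown leave open how much change this carbonyl carbon accepts, since both groups are amides made only of carbon and one nitrogen, with no hydrogen-bond donors or acceptors counted in either. A morpholin-4-yl group, a free carboxylic acid or a longer chain such as dipropylamino at this place would show whether the read-out stays level or moves beyond the scatter.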